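Triazine series: cyclopentylamino for methoxy, alongside a pyrrolidinyl result

This account rests on a few compounds, and the source may have more. Where it says the series, first, only, none or still open, it means among the compounds named here.

Compound 1, `CNc1nc(NC2(C#N)CCCCC2)nc(OC)n1`: 521 nM
Compound 2, `CNc1nc(NC2(C#N)CCCCC2)nc(N2CCCC2)n1`: > 5000 nM

Compound 1 is the reference of the pair. In an in vitro assay on Sf21 cells for inhibition of high affinity 3',5'-cyclic-AMP phosphodiesterase 7A (Homo sapiens) (a lower number here means a stronger inhibitor, a higher number a weaker inhibitor), compound 1 gives 521 nM, and this is the only number shown. For compound 2 the assay reports only a limit, > 5000 nM, so its potency is not known beyond that, as the limit of > 5000 nM in this assay, at which 1 of the 2 values shown sits, notes. Among the compounds with values here, the step of an at least 9.5-fold higher number from compound 1 to compound 2 (0.98 log units; beyond the scatter) is the sole measured step, and it is beyond the scatter.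

Compound 3, `CNc1nc(NC2CCCC2)nc(NC2(C#N)CCCCC2)n1`, is not yet measured in this assay. It differs from compound 1 by cyclopentylamino in place of methoxy on an aromatic carbon. Within the data shown here, the one measured step bears on it directly: the pyrrolidin-1-yl step from compound 1 to compound 2 weakened binding at least modestly, and the cyclopentylamino group occupies the same position on the shared core. Compound 3 is therefore expected to be weaker than compound 1, with a 5.8-fold higher number from compound 1 to compound 3 (0.76 log units; beyond the scatter) as the estimated step. The estimate for compound 3 in this assay is 3000 nM, within 800 nM to 15000 nM, with a real chance that only a limit is reported.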

Compound 3, half-maximal inhibitory concentration: > 5000 nM
Compound 3 gave a limit, no number; the forecaster's own chance of this, stated with the estimate: 40%; middle value at least 1.6-fold (0.22 log units) away from the limit.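

In this assay, cyclopentylamino in place of methoxy gives an at least 9.5-fold higher number from compound 1 to compound 3 (0.98 log units; beyond the scatter), so the position opposite the ring nitrogen now has two replacements that both move away from methoxy, and the loss seen with pyrrolidin-1-yl is not confined to that one group. Both replacements are attached through nitrogen, and within compound 2 and compound 3 the change from a ring nitrogen to a cyclopentyl-bearing amino group cannot be read, since each value is only a limit. The two compounds sit at the same limit of the assay, which sets how far the comparison can go: the limit of > 5000 nM in this assay, at which 2 of the 3 values shown sit.

From the compounds shown here alone, how far compound 2 and compound 3 actually lie beyond that limit remains open. Also open, going by these compounds, is whether ethoxy or dimethylamino at this position would stay close to compound 1, at 521 nM, or fall away in the same manner.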